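This account rests on a few compounds, and the source may have more. Where it says the series, first, only, none or still open, it means among the compounds named here.

Compound 1 `Cn1c(N2N=C(c3ccccc3)CC2c2ccc(F)cc2)nc(-c2ccccc2)c(C#N)c1=O`: 8150 nM
Compound 2 `Cc1ccc(C2=NN(c3nc(-c4ccccc4)c(C#N)c(=O)n3C)C(c3ccc(F)cc3)C2)cc1`: 4620 nM

Both numbers come from a functional assay on HT-29 cells (Homo sapiens) for antiproliferative activity, with a stated time of 72 h; on this read-out lower numbers stand for stronger inhibition and higher numbers for weaker inhibition. Compound 2 stands with the smaller of the two numbers, its nearest neighbour being compound 1; the step of a 1.8-fold lower number from compound 1 to compound 2 (0.25 log units; within the scatter) lies within the scatter, so the two compounds cannot be told apart on this read-out.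

Compound 3 `Cc1ccc(C2=NN(c3nc(-c4ccc(Cl)cc4)c(C#N)c(=O)n3C)C(c3ccc(F)cc3)C2)cc1` has not been measured in this assay. It differs from compound 2 in one place: chloro in place of hydrogen on an aromatic carbon. For the measured compounds named here, no measured step touches this position. Going by the values given here, the only step in hand, a 1.8-fold lower number from compound 1 to compound 2 (0.25 log units; within the scatter), concerns a methyl group on a different aromatic ring, and it was itself within the scatter. There is thus no basis for expecting a step beyond the scatter in this assay, in either direction.

Compound 3 is therefore estimated to give about 3800 nM, with a range from 1200 nM to 12000 nM. That estimate amounts to an expected step of a 1.2-fold lower number from compound 2 to compound 3 (0.08 log units; within the scatter), which is expected to fall within the scatter.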

Compound 3, half-maximal inhibitory concentration: 10500 nM
Beside the measured number, compound 3's estimate is 2.8-fold (0.44 log units) below it; the range from low to high includes it.
By their numbers in this assay, from the lowest: compounds 2, 1 and 3 (each within the scatter of the next, the first and the last beyond it).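

In this assay, for the compounds shown here, the change from phenyl to 4-chlorophenyl gives the first step in this set that lies beyond the scatter (a 2.3-fold higher number from compound 2 to compound 3 (0.36 log units; beyond the scatter)). This shows that the position, on an aromatic carbon and para to a large group, does not accept every change without consequence: a single chlorine atom in place of hydrogen goes with weaker inhibition, though the step is modest and rests on one pair of compounds. Going by these compounds alone, the only earlier step, the methyl change on a different aromatic ring (a 1.8-fold lower number from compound 1 to compound 2 (0.25 log units; within the scatter)), lies within the scatter and could not show this. Nothing in hand explains why the number rises.

With only hydrogen and chloro shown at this position, it remains open whether the rise is particular to chloro or would also appear with another group there, such as a methoxy group, an amine or a carboxylic acid. As far as these compounds go, it is also open whether chloro would have a similar effect without the methyl group that compound 2 and compound 3 share, or at another position on the same ring.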